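A few compounds are considered here, and "the series" means these few. Any claim that something is new, unique, unknown or untested is made for them only; others in the source may bear on it.

Measured compounds and their values:

compound 1, `COc1cc(C(=O)N/N=C/c2ccc(F)c(F)c2)cc(OC)c1OC`, 43.7%
compound 2, `COc1cc(C(=O)N/N=C/c2ccc(C(F)(F)F)cc2)cc(OC)c1OC`, 61.6%
compound 3, `COc1cc(C2=NN(C(C)=O)C(c3ccc(Cl)c(Cl)c3)O2)cc(OC)c1OC`, 26.1%

In a functional assay on PC-3 cells (Homo sapiens) for antiproliferative activity, read by MTT assay, tested at 5 uM (a lower number here means a weaker effect, a higher number a stronger effect of the compound at the concentration tested), compound 2 stands highest of the three numbers. Its nearest neighbour is compound 1, whose value sits well below it, beyond the scatter, and the furthest is compound 3, whose value lies further below still, also beyond the scatter. No two of these compounds differ in only one place, so no single step between measured compounds can be read.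

Compound 4, `COc1cc(C(=O)N/N=C/c2ccc(F)cc2)cc(OC)c1OC`, is the compound not yet measured. It differs from compound 2 in one place: fluoro in place of trifluoromethyl on an aromatic carbon. Fluoro replaces trifluoromethyl on an aromatic carbon of a six-membered aromatic ring of carbon only, para to a large group.

Because compound 2 gives 61.6% and compound 1 gives 43.7%, the expected step from compound 2 to compound 4 is a fall beyond the scatter, a number 16.6 percentage points lower from compound 2 to compound 4 (beyond the scatter). Compound 4 is therefore estimated at 45% in this assay, within a range from 30% to 60%.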

Compound 4, a percentage reported as inhibition, at one concentration (the size of the read-out at that concentration, not a potency): 82.8%
Beside the measured number, compound 4's estimate is 37.8 percentage points below it; measured number above the stated range.
By their numbers in this assay, from the lowest: compound 3; then compound 1; then compound 2; then compound 4.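

In this assay the aromatic carbon para to a large group proves sensitive to what it carries: fluoro in place of trifluoromethyl gives a number 21.2 percentage points higher from compound 2 to compound 4 (beyond the scatter) and so the group of one heavy atom goes with the stronger effect in this pair. Hydrogen in place of fluoro on an aromatic carbon gives a number 39.1 percentage points higher from compound 1 to compound 4 (beyond the scatter) and so the second fluoro of compound 1 goes with a much weaker effect than compound 4 shows. Nothing measured here bears on why either step occurs.

Going by these compounds, it remains open whether hydrogen, a methoxy group, an amine or a carboxylic acid on the carbon that carries fluoro in compound 4 would raise or lower the effect. Compound 3 differs from the others in more than one place, so its steps cannot be read.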